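The source may hold more compounds than are shown below. What is called first, only, known or untested is meant among the compounds shown, and "the series" means these compounds.

Measured in a functional assay with Homo sapiens as the target; a higher number here means a weaker inhibitor, a lower number a stronger inhibitor:
Compound 1 `CC(C)[C@H](NC(=O)COc1cccc2ccccc12)C(=O)N[C@@H](CC(=O)O)C(=O)COc1ccccc1[N+](=O)[O-]`: 27700 nM
Compound 2 `CC(C)[C@H](NC(=O)COc1cccc2ccccc12)C(=O)N[C@@H](CC(=O)O)C(=O)COc1ccc(F)c(F)c1`: 16200 nM
Compound 3 `CC(C)[C@H](NC(=O)COc1cccc2ccccc12)C(=O)N[C@@H](CC(=O)O)C(=O)COc1cc(F)cc(F)c1`: 15900 nM

Compound 3, at 15900 nM, cannot be told apart from the other two, as all three values lie within the scatter of one another. Compound 4 `CC(C)[C@H](NC(=O)COc1cccc2ccccc12)C(=O)N[C@@H](CC(=O)O)C(=O)COc1c(F)cc(F)cc1F` carries 2,4,6-trifluorophenyl in place of 3,5-difluorophenyl on an oxygen on a saturated carbon.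

Three measured swaps of this aryl group bear on the change: a 1.7-fold lower number from compound 1 to compound 2 (0.23 log units; within the scatter), a 1.7-fold lower number from compound 1 to compound 3 (0.24 log units; within the scatter) and a 1.0-fold lower number from compound 2 to compound 3 (0.01 log units; within the scatter). Among the measured compounds shown here, each stayed within the scatter, though no measured compound has a third fluorine. No step beyond the scatter is therefore expected in this assay. The estimated step is a 1.1-fold lower number from compound 3 to compound 4 (0.03 log units; within the scatter). Compound 4 is expected at 15000 nM, with an estimated range of 6500 nM to 32000 nM.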

Compound 4, half-maximal inhibitory concentration: 14900 nM
The estimate for compound 4 lay 1.0-fold (0.00 log units) above the measured number; the measured number falls inside the stated range.
By their numbers in this assay, from the lowest: compounds 4, 3, 2 and 1 (each within the scatter of the next).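

The swap to 2,4,6-trifluorophenyl gives a 1.1-fold lower number from compound 3 to compound 4 (0.03 log units; within the scatter) and a 1.1-fold lower number from compound 2 to compound 4 (0.04 log units; within the scatter) and, set against 2-nitrophenyl, a 1.9-fold lower number from compound 1 to compound 4 (0.27 log units; within the scatter). A third fluorine therefore adds a fourth aryl group on this oxygen that stays within the scatter of the others in this assay, so no aryl group shown here stands apart. Nothing measured explains this flat result. Still open, going by these compounds, is whether an amine or a longer chain in place of the aryl group would move the number beyond the scatter.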